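A few compounds are considered here, and "the series" means these few. Any claim that something is new, unique, unknown or untested is made for them only; others in the source may bear on it.

Compound 3 `CCOC(=O)C1=C(C)NC(C)=C(C(=O)OC)C1c1csc(-c2ccc(Cl)cc2)n1` is the weakest inhibitor among the three measured compounds in an assay on isolated protein for antagonist activity at Voltage-dependent L-type calcium channel subunit alpha-1C (Cavia porcellus), with a stated time of 15 min (a higher number here means a weaker inhibitor, a lower number a stronger inhibitor), where compound 3 gives 22000 nM. Compound 1 `COC(=O)C1=C(C)NC(C)=C(C(=O)OC)C1c1csc(-c2ccc(Cl)cc2)n1` gives 4430 nM in this assay, and compound 2 `CCCOC(=O)C1=C(C)NC(C)=C(C(=O)OCCC)C1c1csc(-c2ccc(Cl)cc2)n1` gives 4800 nM; those two values lie within the scatter of each other. Compound 4 `CCCOC(=O)C1=C(C)NC(C)=C(C(=O)OC)C1c1csc(-c2ccc(Cl)cc2)n1` differs from compound 3 by methyl in place of hydrogen on a saturated chain carbon, two bonds along the chain from an oxygen next to a carbonyl group. Among the compounds with values here, the only measured step that touches this part of the molecule is a 5.0-fold higher number from compound 1 to compound 3 (0.70 log units; beyond the scatter), which lengthened the same ester chain by one carbon and weakened inhibition. Compound 2, which carries the propyl chain on both esters, is not weaker than compound 1, so a longer chain on its own does not always cost potency. Within the data shown here, no measured step covers the ethyl to propyl change, so the expectation is uncertain. Compound 4 is estimated to come out at 12000 nM, with a range of 4000 nM to 36000 nM, meaning an expected step of a 1.8-fold lower number from compound 3 to compound 4 (0.26 log units; within the scatter).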

Compound 4, half-maximal inhibitory concentration: 5920 nM
Compound 4: the middle estimate sits 2.0-fold (0.31 log units) above what was measured; low and high end bracket the measured number.
By their numbers in this assay, from the lowest: compounds 1, 2 and 4 (each within the scatter of the next); then compound 3.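

Lengthening this ester chain from ethyl to propyl gives a clear recovery (a 3.7-fold lower number from compound 3 to compound 4 (0.57 log units; beyond the scatter)), so the loss seen on going from methyl to ethyl (a 5.0-fold higher number from compound 1 to compound 3 (0.70 log units; beyond the scatter)) does not continue as the chain grows. With methyl on the other ester, the methyl and propyl chains at this position are not told apart (a 1.3-fold higher number from compound 1 to compound 4 (0.13 log units; within the scatter)), so among these three chains, only ethyl stands out. With propyl at this position, the other ester can be propyl or methyl without a difference beyond the scatter (a 1.2-fold higher number from compound 2 to compound 4 (0.09 log units; within the scatter)).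

Nothing shown explains why the ethyl ester alone stands apart. From the compounds shown here alone, it also remains open whether a longer chain such as butyl, or a chain ending in an amine, would stay at the level of compound 4.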